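A few compounds are considered here, and "the series" means these few. Any claim that something is new, unique, unknown or untested is made for them only; others in the source may bear on it.

Compound 1 `Cc1cc(C)cc(S(=O)(=O)c2c(C(=O)NC(C)C(=O)NCc3ccccc3F)[nH]c3ccc(Cl)cc23)c1`: 23300 nM
Compound 2 `Cc1cc(C)cc(S(=O)(=O)c2c(C(=O)NC(c3ccc(Cl)cc3)C3CC3)[nH]c3ccc(Cl)cc23)c1`: > 47300 nM
Compound 3 `COc1cccc(F)c1CNC(=O)c1[nH]c2ccc(Cl)cc2c1S(=O)(=O)c1cc(C)cc(C)c1`: > 49900 nM

These three compounds share one core and differ only in the group carried on the amide-type nitrogen. In an ADME assay on MT4 cells (Homo sapiens) for cytotoxicity, read by MTT assay (a lower number here means that less compound is tolerated, a higher number that more compound is tolerated), compound 1 gives 23300 nM, a measured number. For compound 2 the value > 47300 nM is a limit of the assay and not a number, as stated by the limit of > 47300 nM in this assay, at which 1 of the 3 values shown sits. For compound 3 the value > 49900 nM is likewise a limit, given by the limit of > 49900 nM in this assay, at which 1 of the 3 values shown sits. Compound 2 thus stands at a limit, and its step to compound 3, a step that the two limits leave unreadable from compound 2 to compound 3, cannot be sized.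

Compound 4 is `Cc1cc(C)cc(S(=O)(=O)c2c(C(=O)NC(C)c3ccccc3F)[nH]c3ccc(Cl)cc23)c1`. It differs from compound 2 in a group of 9 heavy atoms (8 carbon, 1 fluorine; one six-membered aromatic ring of carbon only) in place of a group of 11 heavy atoms (10 carbon, 1 chlorine; one three-membered non-aromatic ring of carbon only, one six-membered aromatic ring of carbon only), on an amide-type nitrogen. The only measured step among these compounds is the one from compound 2 to compound 3, and the two limits leave it unreadable, so no measured step gives the size of the change to compound 4. Compound 1, carrying a different group on the same nitrogen, gives a number rather than a limit, which shows that a compound of this set can be read in this assay.

Compound 4 is expected to sit near the limit, with an expected step from compound 2 of an at least 1.3-fold lower number from compound 2 to compound 4 (0.13 log units; that floor lies within the scatter). The estimate for compound 4 is 35000 nM, expected to lie between 15000 nM and 70000 nM.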

Compound 4, half-maximal cytotoxic concentration: > 51500 nM
Compound 4: a limit, no number (the forecaster's own chance of this, stated with the estimate: 50%); middle value at least 1.4-fold (0.16 log units) from the limit.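

In this assay, within the data shown here, the one step that can be read is an at least 2.2-fold higher number from compound 1 to compound 4 (0.34 log units; beyond the scatter), and it comes with 2-fluorophenyl in place of (2-fluorobenzyl)carbamoyl on a saturated chain carbon bound to an amide-type nitrogen and a saturated chain carbon. This is the first size that can be put on a change at this position, and it points towards more compound being tolerated, although its true size may be larger, since the value of compound 4 is a limit and not a number: the limit of > 51500 nM in this assay, at which 1 of the 4 values shown sits. Among the four compounds shown, compound 1 alone carries (2-fluorobenzyl)carbamoyl and compound 1 alone gives a number, while the steps among compound 2, compound 3 and compound 4 cannot be read.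

The compounds shown leave open how much of compound 2, compound 3 or compound 4 the cells would tolerate beyond these limits, so these three cannot be ranked against one another. They also leave open whether a different group on that saturated chain carbon, such as a carboxylic acid or an amine, would give a number like that of compound 1 or another limit.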